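The source may report more compounds than this note shows. Statements on the series, on what has been measured and on what is new or still open speak of the compounds shown alone.

Of the compounds shown here, two have been measured in a functional assay on MCF7 cells (Homo sapiens) for antiproliferative activity, read by MTT assay, with a stated time of 72 h; on this read-out higher numbers stand for weaker inhibition and lower numbers for stronger inhibition. Compound 1 `O=C1NC(=S)S/C1=C\C1=Cc2ccccc2OC1` carries a hydrogen on the ring nitrogen of the shared core, and in this assay compound 1 gives 68700 nM. Compound 2 `O=C(O)CN1C(=O)/C(=C/C2=Cc3ccccc3OC2)SC1=S` carries a carboxymethyl group on that nitrogen instead. In this assay compound 2 gives only a limit of the assay, > 100000 nM, and no number. Compound 2 therefore sits at the limit of > 100000 nM in this assay, at which 1 of the 2 values shown sits, the weaker end of what can be reported. The step of an at least 1.4-fold higher number from compound 1 to compound 2 (0.16 log units; that floor lies within the scatter) is thus only a floor on the change, not a measured size.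

Compound 3 `COc1cccc2c1OCC(/C=C1\SC(=S)N(CC(=O)O)C1=O)=C2` keeps the carboxymethyl group of compound 2 and differs from it by methoxy in place of hydrogen on an aromatic carbon. Among the compounds with values here, none of the measured steps touches this aromatic ring; the single measured step concerns the ring nitrogen. So nothing in hand bears on the change from compound 2 to compound 3, and no shift beyond the scatter is expected in this assay. Since compound 2 already stands at the limit, compound 3 is expected to give 150000 nM, within 50000 nM to 500000 nM, most likely again as a limit rather than a number. That corresponds to an expected step that the limit leaves unreadable from compound 2 to compound 3.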

Compound 3, half-maximal inhibitory concentration: > 200000 nM
Compound 3 ended at the assay's limit; the forecaster's own chance of this, stated with the estimate: 70%; middle value at least 1.3-fold (0.12 log units) away from the limit.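

Within the data shown here, compound 2 and compound 3 both stand only as limits of this assay and not as numbers, so no step between them can be read. The compounds shown leave open whether methoxy in place of hydrogen on an aromatic carbon changes the inhibition at all, and if so, in which direction and by how much.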